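This account rests on a few compounds, and the source may have more. Where it says the series, first, only, none or still open, it means among the compounds named here.

Working notes on the series. For the measured compounds named here, in a functional assay on MCF7 cells (Homo sapiens) for antiproliferative activity, read by MTT assay (a higher number here means a weaker inhibitor, a lower number a stronger inhibitor), compound 1 `Cc1c(-n2cc(COc3ccc(/C=C/C(=O)c4cc5c(cc4O)OC(C)(C)CC5)cc3)nn2)cccc1[N+](=O)[O-]` gives 176000 nM as the only number so far. Compound 2 `Cc1ccc(-n2cc(COc3ccc(/C=C/C(=O)c4cc5c(cc4O)OC(C)(C)CC5)cc3)nn2)cc1Br` is recorded as "not active" (no number reported) with no figure, so it has no numerical place in the series. Compound 3 `CCCCCCCCn1cc(COc2ccc(/C=C/C(=O)c3cc4c(cc3O)OC(C)(C)CC4)cc2)nn1` differs from it by octyl in place of 3-bromo-4-methylphenyl on an aromatic nitrogen. Going by the values given here, no measured step covers this change. In this assay the expectation is only a modest shift towards stronger inhibition, leaving compound 3 weak and in the range of compound 1 at 176000 nM, and a second "not active" result remains possible. The estimated value for compound 3 is 80000 nM (expected range 20000 nM to 250000 nM).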

Compound 3, half-maximal inhibitory concentration: "not active" (no number reported)
Compound 3: no number reported; the estimate stays without a comparison.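

Compound 2 and compound 3 are both recorded as not active, without a number, in this assay, so no step can be read between them. The compounds shown leave open how octyl and 3-bromo-4-methylphenyl compare. No further data bear on this result.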